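Cyano in place of ethylcarbamoyl on the chain carbon

The source may hold more compounds than are shown below. What is called first, only, known or untested is meant among the compounds shown, and "the series" means these compounds.

Compound 1 `CCOC(=O)CN(c1ccccc1)[C@H]1c2cc(C#N)ccc2OC(C)(C)[C@@H]1O`: > 30000 nM in a functional assay (aorta) with Rattus norvegicus as the target (on this read-out higher numbers stand for weaker inhibition and lower numbers for stronger inhibition), a limit of the assay.
Compound 2 `CCOC(=O)CCCN(c1ccccc1)[C@H]1c2cc(C#N)ccc2OC(C)(C)[C@@H]1O`: > 30000 nM, a limit.
Compound 3 `CCNC(=O)CN(c1ccccc1)[C@H]1c2cc(C#N)ccc2OC(C)(C)[C@@H]1O`: > 30000 nM, a limit.

All three measured compounds sit at the limit of > 30000 nM in this assay, at which 3 of the 3 values shown sit. Because of that the steps a step that the two limits leave unreadable from compound 1 to compound 2, a step that the two limits leave unreadable from compound 1 to compound 3 and a step that the two limits leave unreadable from compound 2 to compound 3 stay unreadable in size and direction. Compound 3 thus stands at the limit, indistinguishable from compound 1 and compound 2 on these numbers.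

Compound 4 `CC1(C)Oc2ccc(C#N)cc2[C@H](N(CC#N)c2ccccc2)[C@H]1O` carries cyano in place of ethylcarbamoyl on a saturated chain carbon bound to a nitrogen on an aromatic ring. Going by the values given here, no measured step bears readably on this change; the only evidence is that every neighbour of compound 4 sits at the limit. The expected step of a number no higher from compound 3 to compound 4 (the limit leaves the size open) is therefore none that the limit could reveal. Compound 4 is expected to give about 30000 nM, within 10000 nM to 100000 nM, most likely reported again only as a limit.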

Compound 4, half-maximal inhibitory concentration: 59000 nM
Compound 4: middle estimate off by 2.0-fold (0.29 log units), on the low side, within the range that was stated.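

Compound 4 gives 59000 nM in this assay.

No step to compound 4 from compound 1, compound 2 or compound 3 can be read, because compound 1, compound 2 and compound 3 are only limits: the limit of > 30000 nM in this assay, at which 3 of the 4 values shown sit.

The compounds shown leave open whether cyano in place of ethylcarbamoyl changes inhibition at all.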